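Isopropoxy for cyclopropyl on the fused bicyclic core

A few compounds are considered here, and "the series" means these few. Any claim that something is new, unique, unknown or untested is made for them only; others in the source may bear on it.

Two compounds of the series carry a number in a functional assay on HEK293 cells for antagonist activity at proteinase-activated receptor 4 (Homo sapiens), read by FLIPR and calcium flux, with a stated time of 30 min; on this read-out higher numbers stand for weaker inhibition and lower numbers for stronger inhibition. Compound 1 `Cc1nn2cc(-c3cc4ccccc4o3)nc2s1` gives 37 nM and is the lower of the two. Going by the values given here, compound 2 `c1ccc2oc(-c3cn4nc(C5CC5)sc4n3)cc2c1` gives 530 nM, the higher of the two numbers, its only neighbour being compound 1, from which it is separated by the single change of cyclopropyl in place of methyl on an aromatic carbon; that step, a 14-fold higher number from compound 1 to compound 2 (1.16 log units; beyond the scatter), is the only one known in the set.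

Compound 3 `CC(C)Oc1nn2cc(-c3cc4ccccc4o3)nc2s1` is not yet measured. It differs from compound 2 in one place: isopropoxy in place of cyclopropyl on an aromatic carbon. Among the compounds with values here, no measured step covers an alkoxy group at this position; the step from compound 1 to compound 2 only shows that a larger group than methyl at this carbon raised the number substantially. Isopropoxy is again a group of that size, so the expectation is a number close to that of compound 2 rather than a return toward compound 1, with wide uncertainty.

Compound 3 is estimated at 400 nM, within 80 nM to 2000 nM, an expected step of a 1.3-fold lower number from compound 2 to compound 3 (0.12 log units; within the scatter).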

Compound 3, half-maximal inhibitory concentration: 760 nM
The estimate for compound 3 lay 1.9-fold (0.28 log units) below the measured number; measured number inside the range.
By their numbers in this assay, from the lowest: compound 1; then compounds 2 and 3 (each within the scatter of the next).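

In this assay, isopropoxy in place of cyclopropyl gives a 1.4-fold higher number from compound 2 to compound 3 (0.16 log units; within the scatter), so compound 2 and compound 3 cannot be told apart, even though the entering group has no ring and carries one hydrogen-bond acceptor where the leaving group has none. Isopropoxy in place of methyl gives a 21-fold higher number from compound 1 to compound 3 (1.31 log units; beyond the scatter), so a second, different replacement of methyl on this aromatic carbon, next to the ring nitrogen and next to the ring sulfur, also ends far from compound 1, and the large step is no longer tied to cyclopropyl alone. Nothing measured here accounts for how this carbon responds to these groups.

As far as these compounds go, whether methyl is unusual at this carbon, or whether other groups share its low number, stays open, and methoxy, ethyl or a bare hydrogen would bear directly on that. An amine at the same carbon would show whether a hydrogen-bond donor there separates from the flat level shared by compound 2 and compound 3.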